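Replacing but-1-en-1-yl with 2-chloroethyl on a carbonyl carbon

The source may hold more compounds than are shown below. What is called first, only, known or untested is meant among the compounds shown, and "the series" means these compounds.

Three measured compounds share one core and differ in the group on a carbonyl carbon. In a functional assay on HCT-116 cells (Homo sapiens) for inhibition, read by MTT assay, with a stated time of 48 h (on this read-out higher numbers stand for weaker inhibition and lower numbers for stronger inhibition), compound 1 (`COc1ccc(CN(C(C)=O)c2cc(OC)c(OC)c(OC)c2)cc1O`) gives 270 nM and compound 2 (`COc1ccc(CN(C(=O)C=C(C)C)c2cc(OC)c(OC)c(OC)c2)cc1O`) gives 290 nM. The change between them is a 1.1-fold higher number from compound 1 to compound 2 (0.03 log units; within the scatter), so these two cannot be told apart. Compound 3 (`CC/C=C/C(=O)N(Cc1ccc(OC)c(O)c1)c1cc(OC)c(OC)c(OC)c1`) gives 63 nM, the lowest number of the three and so the strongest inhibition so far.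

Compound 4 (`COc1ccc(CN(C(=O)CCCl)c2cc(OC)c(OC)c(OC)c2)cc1O`) has not yet been measured. It carries 2-chloroethyl in place of but-1-en-1-yl on a carbonyl carbon. Within the data shown here, no measured step makes this exact swap. The closest evidence is a 4.3-fold lower number from compound 1 to compound 3 (0.63 log units; beyond the scatter) and a 4.6-fold lower number from compound 2 to compound 3 (0.66 log units; beyond the scatter). These are modest steps of nearly equal size, and each arrives at but-1-en-1-yl from a different group. Among the measured compounds shown here, with only three compounds this is thin evidence, but it suggests that giving up but-1-en-1-yl could cost most of that gain, so a modest rise in the number is expected in this assay. The expected change is a 2.9-fold higher number from compound 3 to compound 4 (0.46 log units; beyond the scatter). For compound 4 the estimated value is 180 nM, within an expected range from 60 nM to 500 nM.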

Compound 4, half-maximal inhibitory concentration: 150 nM
Beside the measured number, compound 4's estimate is 1.2-fold (0.08 log units) above it; measured number inside the range.
By their numbers in this assay, from the lowest: compound 3; then compounds 4, 1 and 2 (each within the scatter of the next).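

In this assay, moving from but-1-en-1-yl to the saturated 2-chloroethyl group gives a 2.4-fold higher number from compound 3 to compound 4 (0.38 log units; beyond the scatter) and, with this third comparison, compound 3 at 63 nM now stands apart from every other group tested on this carbonyl carbon. The new group does not separate from the two weaker compounds, as a 1.9-fold lower number from compound 2 to compound 4 (0.29 log units; within the scatter) and a 1.8-fold lower number from compound 1 to compound 4 (0.26 log units; within the scatter) are both small enough that compound 4 cannot be told apart from either of them. The loss of the double bond cannot by itself account for the gap, since compound 2 also carries a double bond outside the aromatic rings yet falls with the methyl and 2-chloroethyl compounds rather than with compound 3.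

A plain butyl chain would show whether the double bond of but-1-en-1-yl matters when the chain length stays the same, and a longer chain or an amine on the same carbonyl carbon would show how far this position tolerates other groups. Nothing measured here explains why but-1-en-1-yl stands apart from the other three groups.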